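This account rests on a few compounds, and the source may have more. Where it says the series, first, only, none or still open, it means among the compounds named here.

In a physicochemical assay for acid dissociation, compound 1 `C#CCOc1noc2c1CNCC2` gives 7.6 and compound 2 `C=CCOc1noc2c1CNCC2` gives 7.5, so the two stand within the scatter of each other. Compound 3 `C=C(Br)COc1noc2c1CNCC2` departs from compound 2 by a single change, bromo in place of hydrogen on a double-bonded chain carbon bound to a saturated chain carbon. Among the measured compounds shown here, only one measured step bears on this, a number 0.10 log units lower from compound 1 to compound 2 (within the scatter), which puts vinyl in place of ethynyl on a saturated chain carbon bound to an oxygen on an aromatic ring. That step is small, but it does not involve bromo, so it is only a loose guide and gives no firm direction. The expected result for compound 3 is a number 0.10 log units lower from compound 2 to compound 3 (within the scatter), an estimated step that stays within the scatter. For compound 3 the estimated value is 7.4, with an expected range from 7.1 to 7.7.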

Compound 3, acid dissociation constant: 7.6
Compound 3: middle estimate off by 0.20 log units, on the low side, within the range that was stated.
By their numbers in this assay, from the lowest: compounds 2, 1 and 3 (each within the scatter of the next).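

In this assay, bromo in place of hydrogen on a double-bonded chain carbon bound to a saturated chain carbon gives a number 0.10 log units higher from compound 2 to compound 3 (within the scatter), so a single bromine atom at this place leaves the reading within the scatter. Set against the ethynyl group, 1-bromoethenyl on a saturated chain carbon bound to an oxygen on an aromatic ring gives no change at the digits printed from compound 1 to compound 3 (within the scatter), and ethynyl, vinyl and 1-bromoethenyl therefore all stand within the scatter of one another on the shared core. Nothing available accounts for this result.

The compounds shown leave open whether the reading would stay in this band with an amine or a carboxylic acid at this place, or with a longer chain in place of allyl. They also leave open whether chloro or iodo would behave as bromo does here.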